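From Chloro to Nitro in a Small Series

This account rests on a few compounds, and the source may have more. Where it says the series, first, only, none or still open, it means among the compounds named here.

Of the compounds shown here, three built on one shared core have been measured in a functional assay on A549 cells (Homo sapiens) for antiproliferative activity, read by MTT assay, with a stated time of 72 h; a lower number here means a stronger inhibitor, a higher number a weaker inhibitor. Compound 1 `Cc1nc(C)c(/C=C/C(=O)/C=C/c2ccccc2O)nc1C` gives 4780 nM, compound 2 `Cc1nc(C)c(/C=C/C(=O)/C=C/c2ccc(O)cc2)nc1C` gives 4010 nM, and compound 3 `Cc1nc(C)c(/C=C/C(=O)/C=C/c2ccc(Cl)cc2)nc1C` gives 15800 nM. Compound 3 therefore has the highest number of the three and is the weakest inhibitor here, with both of its gaps beyond the scatter.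

The next compound, compound 4 `Cc1nc(C)c(/C=C/C(=O)/C=C/c2ccc([N+](=O)[O-])cc2)nc1C`, has nitro in place of chloro on an aromatic carbon. Among the compounds with values here, no measured compound carries nitro, so the evidence is indirect. The closest step is a 3.9-fold higher number from compound 2 to compound 3 (0.60 log units; beyond the scatter), with chloro in place of hydroxy on an aromatic carbon. The step of a 3.3-fold higher number from compound 1 to compound 3 (0.52 log units; beyond the scatter) is of similar modest size, while the step of a 1.2-fold lower number from compound 1 to compound 2 (0.08 log units; within the scatter) shows that the two hydroxy compounds do not separate. Chloro is thus the one substituent so far tied to a higher number, though it rests on a single compound. Leaving chloro may therefore recover part of that loss, but nothing shows that nitro behaves like hydroxy. The expected step is a 2.0-fold lower number from compound 3 to compound 4 (0.30 log units; within the scatter), small and towards a lower number. Compound 4 is estimated at 8000 nM, with an expected range from 3000 nM to 20000 nM.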

Compound 4, half-maximal inhibitory concentration: 9600 nM
The estimate for compound 4 lay 1.2-fold (0.08 log units) below the measured number; low and high end bracket the measured number.
By their numbers in this assay, from the lowest: compounds 2, 1, 4 and 3 (each within the scatter of the next, the first and the last beyond it).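

In this assay the step of a 1.6-fold lower number from compound 3 to compound 4 (0.22 log units; within the scatter) leaves nitro and chloro unseparated at this position, on an aromatic carbon para to a large group, so this exchange gives no change that can be told from the scatter. The step of a 2.4-fold higher number from compound 2 to compound 4 (0.38 log units; beyond the scatter) is the new finding: chloro is no longer the only substituent at this position tied to a higher number than hydroxy, and the gap to hydroxy now rests on two different groups rather than a single compound. No measurement is available that would explain either step or say what nitro and chloro share.

The compounds shown leave open whether an amine or a carboxylic acid at this position would stay close to the hydroxy compound 2 or fall with chloro and nitro. Within the data shown here, they also leave open whether hydroxy is truly exceptional here, as only chloro and nitro are set against it at this position so far.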